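A few compounds are considered here, and "the series" means these few. Any claim that something is new, unique, unknown or untested is made for them only; others in the source may bear on it.

Measured so far:

Compound 1, `O=C(/C=C\Nc1ccc(Cl)cc1)c1cn(-c2ccccc2)nc1-c1ccccc1`, gives 14100 nM in a functional assay on A549 cells (Homo sapiens) for antiproliferative activity, read by MTT assay, with a stated time of 48 h; a higher number here means a weaker inhibitor, a lower number a stronger inhibitor.
Compound 2, `O=C(/C=C\Nc1ccc(C(F)(F)F)cc1)c1cn(-c2ccccc2)nc1-c1ccccc1`, gives > 50000 nM in this assay; this value is a limit of the assay, not a number.
Compound 3, `O=C(/C=C\Nc1ccc(Cl)cc1)c1cn(-c2ccccc2)nc1-c1ccc(Cl)cc1`, gives 3670 nM in this assay.

All three share one core; they differ only at the edges. Compound 1 and compound 2 differ by trifluoromethyl in place of chloro on an aromatic carbon. That change went with an at least 3.5-fold higher number from compound 1 to compound 2 (0.54 log units; beyond the scatter), and since compound 2 sits at the limit of > 50000 nM in this assay, at which 1 of the 3 values shown sits, only the direction and a floor for the size of the step are known, not its full extent.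

The cores of compound 1 and compound 3 differ by chloro in place of hydrogen on an aromatic carbon, which went with a 3.8-fold lower number from compound 1 to compound 3 (0.58 log units; beyond the scatter); so far compound 3 holds the lowest number of the two that are numbers.

Compound 4, `O=C(/C=C\Nc1ccc(C(F)(F)F)cc1)c1cn(-c2ccccc2)nc1-c1ccc(Cl)cc1`, has not yet been measured. It differs from compound 3 by trifluoromethyl in place of chloro on an aromatic carbon. This is the same change that turns compound 1 into compound 2, made here on the core of compound 3, at the same kind of place. Among the measured compounds shown here, the one time this change has been seen, it weakened inhibition by an at least 3.5-fold higher number from compound 1 to compound 2 (0.54 log units; beyond the scatter), so a step of at least a similar size is expected for compound 4, namely a 4.1-fold higher number from compound 3 to compound 4 (0.61 log units; beyond the scatter). Compound 4 is therefore estimated at 15000 nM in this assay, with a range from 6000 nM to 50000 nM, and a real chance that only a limit is reported.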

Compound 4, half-maximal inhibitory concentration: > 50000 nM
Compound 4 ended at the assay's limit; the forecaster's own chance of this, stated with the estimate: 25%; at least 3.3-fold (0.52 log units) between middle value and limit.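

In this assay compound 4 gives > 50000 nM, which is a limit of the assay and not a number. Replacing (4-chlorophenyl)amino with (4-(trifluoromethyl)phenyl)amino on the core of compound 3 also went with weaker inhibition, with an at least 13-fold higher number from compound 3 to compound 4 (1.13 log units; beyond the scatter), so the direction of this change held on both cores shown. This does not show that the size of the change carried over, and the step from compound 2 to compound 4 cannot be read, so only the direction can be compared: the same change on two cores in this assay, an at least 3.5-fold higher number (0.54 log units; beyond the scatter) from compound 1 to compound 2 and an at least 13-fold higher number (1.13 log units; beyond the scatter) from compound 3 to compound 4; the limit leaves it open whether they differ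

Still open, going by these compounds, is how other groups at this place on the ring, such as a bromo, a methoxy, an amine or a carboxylic acid, would compare with chloro on either core. Also open is how much weaker compound 2 and compound 4 really are, since their true values lie out of reach at the same limit: the limit of > 50000 nM in this assay, at which 2 of the 4 values shown sit.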